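Does the Bromine Matter for Growth Inhibition in Liver Cells

The compounds below may be only part of what the source reports. "The series", "measured", "known", "first", "only" and "open" are said of these compounds alone.

Measured compounds:
compound 1 `CCCCOc1ccc(C(=O)/C=C/c2c(/C=C/c3ccc(OC)cc3)cc(OC)cc2OC)cc1`: 12.9 ug/mL
compound 2 `COc1ccc(/C=C/c2cc(OC)cc(OC)c2/C=C/C(=O)c2ccc(Br)cc2)cc1`: 12.9 ug/mL

In a functional assay on HepG2 cells (Homo sapiens) for antiproliferative activity, read by MTT assay, with a stated time of 48 h (a lower number here means a stronger inhibitor, a higher number a weaker inhibitor), compound 1 gives 12.9 ug/mL. Compound 2 gives 12.9 ug/mL. Compound 2 therefore stands level with compound 1, the step of no change at the digits printed from compound 1 to compound 2 (within the scatter) lying within the scatter. Compound 3 `COc1ccc(/C=C/c2cc(OC)cc(OC)c2/C=C/C(=O)c2ccccc2)cc1` differs from compound 2 by hydrogen in place of bromo on an aromatic carbon. Among the measured compounds shown here, no measured step removes a bromo; the only related step, from compound 1 to compound 2, exchanged butoxy for bromo without any change, giving no sign that this position controls potency. Compound 3 is expected to give about 14 ug/mL, within 7 ug/mL to 28 ug/mL, an expected step of a 1.1-fold higher number from compound 2 to compound 3 (0.04 log units; within the scatter) staying within the scatter.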

Compound 3, half-maximal inhibitory concentration: 6.8 ug/mL
Estimate against measurement, compound 3: 2.1-fold (0.31 log units) above; measured number below the stated range.
By their numbers in this assay, from the lowest: compounds 3, 1 and 2 (each within the scatter of the next).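

The step of a 1.9-fold lower number from compound 2 to compound 3 (0.28 log units; within the scatter) comes from removing the bromo, while a 1.9-fold lower number from compound 1 to compound 3 (0.28 log units; within the scatter) comes from removing the butoxy. The earlier pair compared only two substituents; compound 3 adds the bare phenyl, with plain hydrogen at this ring position. Across these three compounds, neither bromo nor butoxy is shown to be needed for activity. From the compounds shown here alone, whether an amine or a carboxylic acid at this position would also leave the number within the scatter remains open. No evidence here bears on why these three compounds read so closely.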